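Adding a 3-chlorophenylcarbonyl to the ring nitrogen

This account rests on a few compounds, and the source may have more. Where it says the series, first, only, none or still open, it means among the compounds named here.

Measured compounds:
compound 1, `O=C(Nc1ccccc1C(F)(F)F)C1CCc2ccccc2N1`, in a functional assay on MDA-MB-231 cells (Homo sapiens) for cytotoxicity, read by sulforhodamine B assay, with a stated time of 72 h (a higher number here means a weaker inhibitor of growth, a lower number a stronger inhibitor of growth), compound 1 gives 45500 nM.
compound 2, `CCC(=O)N1c2ccccc2CCC1C(=O)Nc1ccccc1C(F)(F)F`. In this assay compound 2 reaches only a limit, > 80000 nM.

As far as these compounds go, compound 2 is the weaker of the two measured compounds, and its value is a limit rather than a number, so its true position is unknown beyond that line (the limit of > 80000 nM in this assay, at which 1 of the 2 values shown sits). For the measured compounds named here, the one measured step, an at least 1.7-fold higher number from compound 1 to compound 2 (0.24 log units; that floor lies within the scatter), replaces the hydrogen on the ring nitrogen with propanoyl, and its floor lies within the scatter.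

Compound 3, `O=C(Nc1ccccc1C(F)(F)F)C1CCc2ccccc2N1C(=O)c1cccc(Cl)c1`, is not yet measured. It differs from compound 2 by 3-chlorophenyl in place of ethyl on a carbonyl carbon. Going by the values given here, no measured step changes the group on this carbonyl carbon, so the only bearing evidence is that acylation of the ring nitrogen did not bring a stronger inhibitor. Compound 3 is therefore expected to stay weak, with an estimate of 70000 nM, between 20000 nM and 200000 nM. The step of an at least 1.1-fold lower number from compound 2 to compound 3 (0.05 log units; that floor lies within the scatter) is expected to be no more than the scatter, and a limit again is likely.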

Compound 3, concentration for 50% growth inhibition: 288 nM
Compound 3: middle estimate off by 240-fold (2.39 log units), on the high side; measured number outside the range, below it.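

The group on the carbonyl carbon, and not just the presence of a carbonyl on the ring nitrogen, decides the outcome in this assay: swapping ethyl for 3-chlorophenyl gives an at least 270-fold lower number from compound 2 to compound 3 (2.44 log units; beyond the scatter). Acylating the ring nitrogen therefore does not by itself lead to a weak inhibitor, since the (3-chlorophenyl)carbonyl group gives a 160-fold lower number from compound 1 to compound 3 (2.20 log units; beyond the scatter), whereas the floor of the step with propanoyl stays within the scatter. The change from ethyl to 3-chlorophenyl could be larger still, as its size is only a floor set by compound 2, whose value is a limit: the limit of > 80000 nM in this assay, at which 1 of the 3 values shown sits.

The compounds shown do not separate the contribution of the aromatic ring from that of the chlorine, a question that a plain phenyl on this carbonyl carbon would address, while a cyclohexyl or a longer chain would test whether an aromatic ring is needed at all. They also leave open whether the (3-chlorophenyl)carbonyl group would give a similar gain if the rest of the shared core were changed.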